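From a dichlorophenoxy arm to a fluorophenylsulfanyl arm

The compounds below may be only part of what the source reports. "The series", "measured", "known", "first", "only" and "open" are said of these compounds alone.

Compound 1 `Nc1cc(N)c2nc(-c3ccccc3)c(Oc3ccc(Cl)c(Cl)c3)nc2c1` has been tested in a functional assay on NCI-H322M cells (Homo sapiens) for inhibition, read by sulforhodamine B assay, with a stated time of 48 h (on this read-out higher numbers stand for lower toxicity in this test and lower numbers for higher toxicity in this test), where compound 1 gives < 100000 nM, a value that is a limit of the assay and not a number. Compound 2 `CCOC(=O)[C@H](CCC(=O)O)NC(=O)c1ccc(CNc2nc3cc(N)cc(N)c3nc2-c2ccccc2)cc1` gives < 100000 nM in this assay, and this too is only a limit. Compound 3 `COc1ccc(CNc2nc3cc(N)cc(N)c3nc2-c2ccccc2)cc1` likewise gives < 100000 nM in this assay, again a limit. Within the data shown here, all three compounds thus sit at the limit of < 100000 nM in this assay, at which 3 of the 3 values shown sit, so no order among compounds 1, 2 and 3 can be read from these numbers, and no step between two measured compounds is available to guide an estimate.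

Compound 4 `Nc1cc(N)c2nc(-c3ccccc3)c(Sc3ccc(F)cc3)nc2c1` differs from compound 1 in one place: (4-fluorophenyl)sulfanyl in place of 3,4-dichlorophenoxy on an aromatic carbon. With every value shown being a limit, there is nothing in the measured data that would point to a change in either direction for this exchange. The expected step is a step that the limit leaves unreadable from compound 1 to compound 4, which is meant to lie within the usual scatter. Compound 4 is therefore estimated at 30000 nM, with a range from 5000 nM to 100000 nM, and it is expected that this assay will again report only a limit rather than a number.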

Compound 4, concentration lethal to 50% of the cells: 70800 nM
Estimate against measurement, compound 4: 2.4-fold (0.37 log units) below, and the stated range covers the measured number.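

Among these compounds, compound 4 now has a measured number, but compound 1 has only a limit, so no step between compound 1 and compound 4 can be read: the limit of < 100000 nM in this assay, at which 3 of the 4 values shown sit. From the compounds shown here alone, how far (4-fluorophenyl)sulfanyl in place of 3,4-dichlorophenoxy on an aromatic carbon shifts the result in this assay therefore stays open.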